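Para substituent swaps on the benzamide end of the series

This account rests on a few compounds, and the source may have more. Where it says the series, first, only, none or still open, it means among the compounds named here.

The three measured compounds share one core. Compound 1 `COc1ccccc1N1CCN(CCCCNC(=O)c2ccc([N+](=O)[O-])cc2)CC1` carries nitro, compound 2 `COc1ccccc1N1CCN(CCCCNC(=O)c2ccc(I)cc2)CC1` carries iodo and compound 3 `COc1ccccc1N1CCN(CCCCNC(=O)c2ccc(N)cc2)CC1` carries amino at the same aromatic carbon. In an assay on frontal cortex for binding affinity to Adrenergic receptor alpha-1 (Rattus norvegicus), read by radioligand binding (on this read-out higher numbers stand for weaker inhibition and lower numbers for stronger inhibition), compound 1 gives 14 nM, compound 2 gives 15 nM and compound 3 gives 23 nM. Compound 3 therefore sits inside one band with the other two: the step of a 1.6-fold higher number from compound 1 to compound 3 (0.22 log units; within the scatter) and the step of a 1.5-fold higher number from compound 2 to compound 3 (0.19 log units; within the scatter) are both within the scatter, as is the step of a 1.1-fold higher number from compound 1 to compound 2 (0.03 log units; within the scatter) between the other pair.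

Compound 4 `COc1ccccc1N1CCN(CCCCNC(=O)c2ccc(O)cc2)CC1` is the next member. Its difference from compound 3 is hydroxy in place of amino on an aromatic carbon. All three measured steps bear on this change, since each of them exchanges the group at this same aromatic carbon, and none of them moved the number beyond the scatter. On that basis no step beyond the scatter is expected in this assay for compound 4 in either direction, that is a step of about a 1.2-fold lower number from compound 3 to compound 4 (0.06 log units; within the scatter).

Compound 4 is accordingly estimated at 20 nM in this assay, with a range from 8 nM to 50 nM.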

Compound 4, inhibition constant: 17 nM
Beside the measured number, compound 4's estimate is 1.2-fold (0.07 log units) above it, within the range that was stated.
By their numbers in this assay, from the lowest: compounds 1, 2, 4 and 3 (each within the scatter of the next).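

Hydroxy is a fourth group at this aromatic carbon, and it stays in the same band in this assay: a 1.4-fold lower number from compound 3 to compound 4 (0.13 log units; within the scatter), a 1.1-fold higher number from compound 2 to compound 4 (0.05 log units; within the scatter) and a 1.2-fold higher number from compound 1 to compound 4 (0.08 log units; within the scatter) are all within the scatter. The step from amino to hydroxy adds a different kind of comparison to the earlier swaps, as the two groups match in the computed counts of heavy atoms, hydrogen-bond donors and hydrogen-bond acceptors and in having no net charge, and the exchange of nitrogen for oxygen at this carbon leaves the number within the scatter. Nothing measured here accounts for the flat response across nitro, iodo, amino and hydroxy at this carbon.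

On these data alone, whether the band holds for a carboxylic acid, a quaternary ammonium group or a bulkier group such as benzyloxy at this same carbon remains open. Also open is whether a longer chain in place of the one in the shared core would leave the four-member band intact, as every step shown keeps the rest of the core fixed.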